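The compounds below may be only part of what the source reports. "The series", "measured", "known", "first", "only" and "open" are said of these compounds alone.

Within the data shown here, in a functional assay on the whole organism for antagonist activity, with Mus musculus as the target (a lower number here means that less compound is needed, a higher number that more compound is needed for the effect), compound 1 (`COC(=O)N(C)CC#CCn1cncc1C`) gives 5.4 mg/kg, the only full number so far. Compound 2 (`Cn1ccn(CC#CCN2CCCC2)c1=O`) gives > 10 mg/kg, which is a limit of the assay. Compound 3 (`Cn1ccn(CC#CCn2ccnc2)c1=O`) gives > 100 mg/kg, which is also a limit, so its standing is known only as the limit of > 100 mg/kg in this assay, at which 1 of the 3 values shown sits, and the one other limit among the three results is the limit of > 10 mg/kg in this assay, at which 1 of the 3 values shown sits.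

Compound 4 (`Cc1cncn1CC#CCn1ccn(C)c1=O`) differs from compound 3 by one small change: methyl in place of hydrogen on an aromatic carbon. Among the measured compounds shown here, the only measured step that touches this part of the molecule is a step that the two limits leave unreadable from compound 2 to compound 3, and it gives no size to carry over. For the measured compounds named here, no measured step shows what this methyl does on its own. The one pointer is indirect: compound 1 also carries a methyl on an aromatic carbon of such a ring, and it gives 5.4 mg/kg, though the rest of its structure differs.

A move towards less compound needed in this assay is therefore expected, with wide uncertainty, and the expected step is an at least 2.2-fold lower number from compound 3 to compound 4 (0.34 log units; beyond the scatter). A result reported only as a limit remains quite possible. Compound 4 is estimated at 45 mg/kg, with an expected range from 8 mg/kg to 200 mg/kg.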

Compound 4, dose for half-maximal effect: 22 mg/kg
Beside the measured number, compound 4's estimate is 2.0-fold (0.31 log units) above it; the measured number falls inside the stated range.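

Before this result, nothing gave a size for a methyl on this ring: the one step touching this part of the molecule could not be read, and compound 1 differs from the others in more than one place. In this assay, methyl in place of hydrogen on an aromatic carbon, next to the ring nitrogen and next to the ring atom that bears a large group, gives an at least 4.5-fold lower number from compound 3 to compound 4 (0.65 log units; beyond the scatter) and thus shows that this one change alone moves the number beyond the scatter, with the rest of the molecule the same. The printed size is only a lower bound, and its true size stays unknown, since compound 3 is known only as a limit of the assay: the limit of > 100 mg/kg in this assay, at which 1 of the 4 values shown sits.

The compounds shown leave open whether a larger group at this place, such as ethyl or trifluoromethyl, would move the number further or back again. They also leave open whether a methyl on another carbon of this ring would do the same, and whether this step would hold on a different core.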